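Furan for oxadiazole on the shared core: expected potency

A few compounds are considered here, and "the series" means these few. Any claim that something is new, unique, unknown or untested is made for them only; others in the source may bear on it.

The three measured compounds share one core carrying a five-membered heteroaryl group, compared in a functional assay for activation of Alpha-1B adrenergic receptor (Homo sapiens), read by calcium flux; a lower number here means that less compound is needed, a higher number that more compound is needed for the effect. Among the measured compounds shown here, compound 3 `Cc1nc(-c2ccccc2NCC2=NCCN2)no1` gives 676 nM in this assay, the only number among the three. Compound 1 `Cc1nc(-c2ccccc2NCC2=NCCN2)co1` gives only a limit, < 5020 nM. Compound 2 `c1ccc(-c2cnoc2)c(NCC2=NCCN2)c1` likewise gives only a limit, < 100000 nM. The steps a step that the limit leaves unreadable from compound 1 to compound 3, a step that the limit leaves unreadable from compound 2 to compound 3 and a step that the two limits leave unreadable from compound 1 to compound 2 therefore carry no readable size, since the limit of < 5020 nM in this assay, at which 1 of the 3 values shown sits, and the limit of < 100000 nM in this assay, at which 1 of the 3 values shown sits, leave both direction and magnitude open.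

Compound 4 `Cc1ccc(-c2ccccc2NCC2=NCCN2)o1` is not yet measured; it differs from compound 3 by 5-methylfuran-2-yl in place of 5-methyl-1,2,4-oxadiazol-3-yl on an aromatic carbon. For the measured compounds named here, none of the measured steps covers a change to a ring with a single hetero atom, and none has a readable size, so no direction can be expected beyond the scatter and the uncertainty is wide. Compound 4 is estimated at 1500 nM in this assay, with a range from 250 nM to 10000 nM. The step of a 2.2-fold higher number from compound 3 to compound 4 (0.35 log units; beyond the scatter) is expected to centre on no change.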

Compound 4, half-maximal effective concentration: 46.8 nM
Compound 4: the middle estimate sits 32-fold (1.51 log units) above what was measured; measured number outside the range, below it.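

In this assay, among the compounds shown here, 5-methylfuran-2-yl in place of 5-methyl-1,2,4-oxadiazol-3-yl gives a 14-fold lower number from compound 3 to compound 4 (1.16 log units; beyond the scatter), the first step of readable size at this position on the shared core. It shows that this position responds strongly to the choice of five-membered aromatic ring, even though both groups hold 6 heavy atoms: the ring entering has 1 hetero atom and the ring leaving has 3. The steps from compound 1 and compound 2 to compound 4 cannot be read: both of those compounds give only limits.

Which of the ring nitrogens or the placement of the ring oxygen tracks with the step cannot be told from this single pair. From the compounds shown here alone, the part played by the methyl group on the furan stays open, as does how a 5-methylthiophen-2-yl or a plain phenyl group at this position would compare with compound 4.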